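Enantiomer Pair on the Pyrrolidine Sulfonamide Series

This account rests on a few compounds, and the source may have more. Where it says the series, first, only, none or still open, it means among the compounds named here.

Measured so far:
- compound 1, `CSC1=NCCCN1S(=O)(=O)c1ccc(Cl)cc1`, 14800 nM
- compound 2, `O=S(=O)(c1ccc(Cl)cc1)N1CCC[C@H]1c1cccs1`, 2060 nM

In a functional assay on ileum (Cavia porcellus) for inhibition (on this read-out lower numbers stand for stronger inhibition and higher numbers for weaker inhibition), compound 1 gives 14800 nM. In this assay compound 2 gives 2060 nM, which is the lowest of the two numbers at hand; its gap to compound 1 is beyond the scatter, so compound 2 stands as the stronger inhibitor of the pair.

The next compound, compound 3, `O=S(=O)(c1ccc(Cl)cc1)N1CCC[C@@H]1c1cccs1`, is the mirror image of compound 2 at its single stereocentre: the two compounds have the same atoms and bonds and differ only in configuration as drawn: 1 of 1 stereo elements differ; a stereocentre at a saturated ring carbon is drawn S in compound 2 and R in compound 3. Among the compounds with values here, no step between two measured compounds of the same kind exists in this set, so the size of the change is open. Such an inversion can leave the number almost unchanged or shift it either way; the usual outcome in a small set like this is a weaker inhibitor for the other configuration, though a drop within the scatter is also plausible. The step expected from compound 2 to compound 3 is a 2.4-fold higher number from compound 2 to compound 3 (0.39 log units; beyond the scatter), toward a higher number. For compound 3 the estimate in this assay is 5000 nM, with a range from 1200 nM to 25000 nM.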

Compound 3, half-maximal inhibitory concentration: 1070 nM
Beside the measured number, compound 3's estimate is 4.7-fold (0.67 log units) above it, and the stated range ends above it.
By their numbers in this assay, from the lowest: compounds 3 and 2 (each within the scatter of the next); then compound 1.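

In this assay, inverting the stereocentre at the saturated ring carbon gives a 1.9-fold lower number from compound 2 to compound 3 (0.28 log units; within the scatter). Within the data shown here, this is the first matched step, and it shows that the read-out does not separate the S and R configurations as drawn at this position, a question the earlier compounds could not address because they contained no such pair. Any reading of this step can concern configuration alone, as no atom or bond enters or leaves: the fact that compounds 2 and 3 differ only in the configuration as drawn.

A single pair cannot show whether this tolerance of either configuration holds once another part of the shared core changes, so it remains a finding about compound 2 and compound 3 only. As far as these compounds go, it is also open how this assay would respond to an amine, a carboxylic acid or a longer chain on the shared core, and whether compound 2 and compound 3 would remain within the scatter of each other with such a group present.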